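The source may report more compounds than this note shows. Statements on the series, on what has been measured and on what is new or still open speak of the compounds shown alone.

Among the compounds with values here, in a functional assay on A549 cells (Homo sapiens) for inhibition, read by MTT assay, with a stated time of 48 h (a higher number here means a weaker inhibitor, a lower number a stronger inhibitor), compound 3 `COc1ccc2c(=O)c(/C=C/C(=O)NCc3ccc(F)cc3F)coc2c1` gives 13300 nM, the only actual number in this small set. Compound 1 `O=C(/C=C/c1coc2cc(O)ccc2c1=O)NCc1ccccc1` gives > 100000 nM, which is a limit of the assay and not a number. Compound 2 `O=C(/C=C/c1coc2cc(O)ccc2c1=O)NCc1ccc(F)cc1` gives > 100000 nM, which is also a limit. Compound 4 `O=C(/C=C/c1coc2cc(O)ccc2c1=O)NCc1ccc(F)cc1F` has not been measured yet. It differs from compound 3 by one change, hydrogen in place of methyl on an oxygen on an aromatic ring, or methoxy to hydroxy. Within the data shown here, the one measured step, a step that the two limits leave unreadable from compound 1 to compound 2, concerns fluoro and has no readable size, so it offers no size to carry over. More telling is that compound 1 and compound 2 both carry the hydroxy and both sit at the limit of > 100000 nM in this assay, at which 2 of the 3 values shown sit. A rise in the number, meaning a weaker inhibitor in this assay, is therefore expected, and the expected step is a 6.0-fold higher number from compound 3 to compound 4 (0.78 log units; beyond the scatter). For compound 4 the estimate is 80000 nM, with an expected range of 30000 nM to 150000 nM.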

Compound 4, half-maximal inhibitory concentration: 6610 nM
For compound 4 the middle estimate is 12-fold (1.08 log units) above the measured one; the whole stated range lies above it.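

In this assay, hydrogen in place of methyl on an oxygen on an aromatic ring, or methoxy to hydroxy, gives a 2.0-fold lower number from compound 3 to compound 4 (0.30 log units; within the scatter), so this pair shows no readable difference between the two groups. The hydroxy alone therefore does not hold a compound at the limit of the assay, which is a limit and not a number: the limit of > 100000 nM in this assay, at which 2 of the 4 values shown sit. The 2,4-difluorophenyl group instead marks the clear difference among the hydroxy compounds: fluoro in place of hydrogen on an aromatic carbon gives an at least 15-fold lower number from compound 2 to compound 4 (1.17 log units; beyond the scatter), and 2,4-difluorophenyl in place of phenyl gives an at least 15-fold lower number from compound 1 to compound 4 (1.17 log units; beyond the scatter).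

From the compounds shown here alone, the step between the two limits cannot be read, so what the first fluoro contributes on its own stays open. Also open, going by these compounds, is how an amine or a carboxylic acid in this place on the aromatic ring would compare with methoxy and hydroxy.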